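Hydroxyphenyl position within a three-aryl series

This account rests on a few compounds, and the source may have more. Where it says the series, first, only, none or still open, it means among the compounds named here.

Three measured compounds share one set of atoms joined in different ways. In a functional assay on DU-145 cells (Homo sapiens) for cytotoxicity, read by CCK-8 assay and cell counting, with a stated time of 2 days (on this read-out lower numbers stand for stronger inhibition and higher numbers for weaker inhibition), compound 1 `Oc1ccc(-c2cc(-c3ccc(Cl)cc3)nc(-c3cccnc3)c2)cc1` gives 22800 nM. Compound 2 `Oc1ccc(-c2cc(-c3cccs3)nc(-c3ccccc3Cl)c2)cc1` gives 4190 nM in this assay. Compound 3 `Oc1cccc(-c2cc(-c3ccc(Cl)cc3)nc(-c3cccs3)c2)c1` gives 11600 nM in this assay, the second highest of the three numbers; its nearest neighbour is compound 1, within the usual scatter, and its furthest is compound 2, a gap beyond the scatter.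

Compound 4 `Oc1ccc(-c2cc(-c3ccc(Cl)cc3)nc(-c3cccs3)c2)cc1` is compound 3 with one change: 4-hydroxyphenyl in place of 3-hydroxyphenyl on an aromatic carbon, meta to a 4-chlorophenyl group, meta to a thiophen-2-yl group and opposite the ring nitrogen. Among the compounds with values here, no measured pair isolates this change; compound 1 and compound 2 both carry 4-hydroxyphenyl, but each differs from compound 3 in other places as well, so neither settles the direction. In this assay no step beyond the scatter is expected for compound 4, in either direction. Compound 4 is estimated at 10000 nM, with a range from 3500 nM to 30000 nM, which means an expected step of a 1.2-fold lower number from compound 3 to compound 4 (0.06 log units; within the scatter).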

Compound 4, half-maximal inhibitory concentration: 7660 nM
Compound 4: middle estimate off by 1.3-fold (0.12 log units), on the high side, within the range that was stated.
By their numbers in this assay, from the lowest: compounds 2, 4, 3 and 1 (each within the scatter of the next, the first and the last beyond it).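

The position opposite the ring nitrogen now has a direct reading in this assay: 4-hydroxyphenyl in place of 3-hydroxyphenyl gives a 1.5-fold lower number from compound 3 to compound 4 (0.18 log units; within the scatter), so the placement of the hydroxyl on this ring moves the number only within the scatter in this pair. Within the data shown here, compound 4 also links the earlier compounds: 4-chlorophenyl in place of 2-chlorophenyl gives a 1.8-fold higher number from compound 2 to compound 4 (0.26 log units; within the scatter), while thiophen-2-yl in place of pyridin-3-yl gives a 3.0-fold lower number from compound 1 to compound 4 (0.47 log units; beyond the scatter), the only one of these steps beyond the scatter. No measurement available here explains the size of any of these steps.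

As far as these compounds go, a phenyl group carrying an amine or a carboxylic acid at this position remains open. So does whether the hydroxyl shift gives a similar step in the presence of pyridin-3-yl or 2-chlorophenyl.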